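The compounds below may be only part of what the source reports. "The series", "measured", "known", "first", "only" and "open" are said of these compounds alone.

Compound 1 `CCc1cc(C(C)=O)c(O)cc1OCCCCCC(C)(C)C#N` — 85%
Compound 2 `CCc1cc(C(C)=O)c(O)cc1OCCCCCC(C)(C)c1nnn(C)n1` — 95%
Compound 3 `C=CCc1cc(C(C)=O)c(O)cc1OCCCCCC(C)(C)O` — 98%

In an assay on isolated protein for inhibition of leukotriene B4 receptor 1 (Homo sapiens), tested at 10 uM (a higher number here means more inhibition at the concentration tested (going by the name of the read-out), a lower number less inhibition), compound 2 gives 95%, the second highest of the three numbers. Compound 3 stands nearest to it with 98%, a gap within the scatter, and compound 1 stands furthest with 85%, a gap also within the scatter. Compound 4 `CCc1cc(C(C)=O)c(O)cc1OCCCCCCc1nnn[nH]1` has not yet been measured. It differs from compound 2 in one place: (1H-tetrazol-5-yl)methyl in place of 1-methyl-1-(2-methyl-2H-tetrazol-5-yl)ethyl on a saturated chain carbon, five bonds along the chain from an oxygen on an aromatic ring. Among the measured compounds shown here, the only measured step at this place is a number 10 percentage points higher from compound 1 to compound 2 (within the scatter), in which a 2-methyl-2H-tetrazol-5-yl group stood in place of cyano; that step lay within the scatter. For the measured compounds named here, the present change is larger in kind, since the entering group is smaller and carries one hydrogen-bond donor where the leaving group had none, and no measured pair covers such a swap. Given that all three measured numbers are high and the one related step was within the scatter, the step of a number 10 percentage points lower from compound 2 to compound 4 (within the scatter) is expected to be small, with a slight lean downward to allow for the untested change. Compound 4 is therefore estimated at 85%, in a range from 65% to 98%.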

Compound 4, a percentage reported as inhibition, at one concentration (the size of the read-out at that concentration, not a potency): 91%
Compound 4: middle estimate off by 6 percentage points, on the low side, within the range that was stated.
By their numbers in this assay, from the lowest: compounds 1, 4, 2 and 3 (each within the scatter of the next, the first and the last beyond it).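

In this assay the smaller (1H-tetrazol-5-yl)methyl group, with a hydrogen-bond donor that the leaving group lacks, gives a number 4 percentage points lower from compound 2 to compound 4 (within the scatter) and so leaves the read-out at this place on the chain without a step beyond the scatter. Set against the nitrile-bearing group, it gives a number 6 percentage points higher from compound 1 to compound 4 (within the scatter) and thus adds a second tetrazole-bearing group to the one earlier step at this place, again with no step beyond the scatter. No measurement here gives a reason for either step.

The change from compound 2 to compound 4 alters the branching and the tetrazole methyl at once, and these compounds leave their separate shares open. They also leave open how a carboxylic acid, an amine or a longer chain would read at this place in this assay at the same single concentration.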